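The source may hold more compounds than are shown below. What is called first, only, known or untested is meant among the compounds shown, and "the series" means these compounds.

Of the compounds shown here, three sharing one core have been measured in a functional assay on HepG2 cells (Homo sapiens) for cytotoxicity, read by MTT assay, with a stated time of 24 h; a higher number here means a weaker inhibitor, a lower number a stronger inhibitor. Compound 1 `CN1C/C(=C\c2cccnc2)C(=O)/C(=C/c2ccccc2F)C1` gives 4810 nM, compound 2 `CN1C/C(=C\c2ccncc2)C(=O)/C(=C/c2ccccc2F)C1` gives 4600 nM, and compound 3 `CN1C/C(=C\c2ccncc2)C(=O)/C(=C/c2cc([N+](=O)[O-])ccc2F)C1` gives 5200 nM. Compound 2 therefore stands within the scatter of both others, and the three values cannot be ranked. Compound 4 `O=C1/C(=C/c2ccncc2)CN(S(=O)(=O)c2ccc(F)cc2)C/C1=C\c1ccccc1F` has not yet been measured in this assay. It departs from compound 2 at a single place, with (4-fluorophenyl)sulfonyl in place of methyl on an amine nitrogen in a ring.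

Two measured steps are available, and neither touches that nitrogen. Pyridin-4-yl in place of pyridin-3-yl gave a 1.0-fold lower number from compound 1 to compound 2 (0.02 log units; within the scatter), and nitro in place of hydrogen on an aromatic carbon gave a 1.1-fold higher number from compound 2 to compound 3 (0.05 log units; within the scatter). Both lie within the scatter, so they show only that these two edits elsewhere on the core left the number where it was. All three measured compounds carry methyl on the nitrogen, so the data hold no direct measure of the new group. The change is large and untested here, and a moderate step toward a lower number is expected, held only loosely. The estimated step is a 1.8-fold lower number from compound 2 to compound 4 (0.26 log units; within the scatter). Compound 4 is expected at 2500 nM, with an estimated range from 600 nM to 9000 nM.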

Compound 4, half-maximal inhibitory concentration: 20300 nM
Compound 4: middle estimate off by 8.1-fold (0.91 log units), on the low side, and the stated range ends below it.
By their numbers in this assay, from the lowest: compounds 2, 1 and 3 (each within the scatter of the next); then compound 4.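

In this assay, among these compounds, the amine nitrogen in the ring is the first place on the shared core where an edit moves the number beyond the scatter: (4-fluorophenyl)sulfonyl in place of methyl gives a 4.4-fold higher number from compound 2 to compound 4 (0.64 log units; beyond the scatter) and so a modestly weaker inhibitor. The earlier edits, pyridin-4-yl for pyridin-3-yl and nitro for hydrogen on an aromatic carbon, had both stayed within the scatter, so among the compounds shown this nitrogen is the only position at which the number responds, and the response is toward weaker inhibition rather than stronger. Nothing shown here bears on what lies behind this step.

With a single replacement at the nitrogen, the sulfonyl link and the 4-fluorophenyl ring cannot be told apart, and a methylsulfonyl, an acetyl or a benzyl group on the same nitrogen would be needed to separate their shares of the step. From the compounds shown here alone, it also stays open whether the same replacement would move the number in the same way on the core of compound 1 or compound 3, which carry pyridin-3-yl and nitro.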